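Replacing the pyrrole arm of compound 3 with a pyridine

The compounds below may be only part of what the source reports. "The series", "measured", "known", "first", "only" and "open" are said of these compounds alone.

Compound 3 `CCOC(=O)C1=C(Nc2ccccc2)S/C(=C\c2ccc[nH]2)C1=O` stands highest of the three numbers in a functional assay on JAR cells (Homo sapiens) for inhibition, read by MTT assay, with a stated time of 72 h, tested at 10 uM; on this read-out higher numbers stand for more inhibition at the one concentration tested (going by the name of the read-out) and lower numbers for less inhibition: compound 3 gives 49.2%, while compound 1 `CCOC(=O)C1=C(Nc2ccccc2)S/C(=C\c2ccc(OC)cc2)C1=O` gives 32.9% and compound 2 `CCOC(=O)C1=C(Nc2ccccc2)S/C(=C\c2ccc(C(=O)O)cc2)C1=O` gives 16.8%. Compound 4 `CCOC(=O)C1=C(Nc2ccccc2)S/C(=C\c2cccnc2)C1=O` differs from compound 3 in one place: pyridin-3-yl in place of 1H-pyrrol-2-yl on a double-bonded chain carbon bound to a double-bonded ring carbon. Among the measured compounds shown here, the steps that bear on this arm are a number 16.3 percentage points higher from compound 1 to compound 3 (beyond the scatter) and a number 32.4 percentage points higher from compound 2 to compound 3 (beyond the scatter), both gains on moving to the 1H-pyrrol-2-yl group; a number 16.1 percentage points lower from compound 1 to compound 2 (beyond the scatter) shows the two six-membered groups also differ. With pyridin-3-yl entering, a drop back toward the level of compound 1 is expected, estimated as a number 19.2 percentage points lower from compound 3 to compound 4 (beyond the scatter). Compound 4 is therefore expected to give about 30% in this assay, in the range 12% to 50%.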

Compound 4, a percentage reported as inhibition, at one concentration (the size of the read-out at that concentration, not a potency): 32.1%
For compound 4 the middle estimate is 2.1 percentage points below the measured one, within the range that was stated.
By their numbers in this assay, from the lowest: compound 2; then compounds 4 and 1 (each within the scatter of the next); then compound 3.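

In this assay, pyridin-3-yl does not keep what 1H-pyrrol-2-yl gives at this position, with a number 17.1 percentage points lower from compound 3 to compound 4 (beyond the scatter), so a nitrogen-containing aromatic ring alone does not bring the higher number. The pyridine cannot be told apart from 4-methoxyphenyl, with a number 0.8 percentage points lower from compound 1 to compound 4 (within the scatter), yet it stands clear of 4-carboxyphenyl, with a number 15.3 percentage points higher from compound 2 to compound 4 (beyond the scatter). Nothing available here accounts for these steps.

The compounds shown do not separate ring size from the pyrrole's ring hydrogen on nitrogen. A furan-2-yl or 1-methylpyrrol-2-yl group at this position would bear on that question.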